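Replacing 4-bromophenyl with 2,4-difluorophenyl on the shared core

The source may hold more compounds than are shown below. What is called first, only, known or untested is meant among the compounds shown, and "the series" means these compounds.

In a functional assay on MDA-MB-231 cells (Homo sapiens) for inhibition, read by MTT assay, with a stated time of 5 days (a higher number here means a weaker inhibitor, a lower number a stronger inhibitor), compound 3 `Cc1cc(Nc2nc(NCc3ccc(Br)cc3)nc3[nH]ncc23)n[nH]1` gives 1860 nM, the lowest of the three numbers. Compound 2 `Cc1cc(Nc2nc(NCc3cccc(Cl)c3)nc3[nH]ncc23)n[nH]1` gives 6860 nM, and compound 1 `Cc1cc(Nc2nc(NCc3ccccc3F)nc3[nH]ncc23)n[nH]1` gives 9850 nM. Compound 4 `Cc1cc(Nc2nc(NCc3ccc(F)cc3F)nc3[nH]ncc23)n[nH]1` has 2,4-difluorophenyl in place of 4-bromophenyl on a saturated chain carbon bound to a nitrogen on an aromatic ring. Among the measured compounds shown here, two steps bear most directly on this change: a 5.3-fold lower number from compound 1 to compound 3 (0.72 log units; beyond the scatter) and a 3.7-fold lower number from compound 2 to compound 3 (0.57 log units; beyond the scatter), both modest and beyond the scatter. The remaining step, a 1.4-fold lower number from compound 1 to compound 2 (0.16 log units; within the scatter), lies within the scatter. The 2-fluorophenyl of compound 1 is the nearest measured group, so part of the gain in this assay is expected to be lost. The expected change is a 2.4-fold higher number from compound 3 to compound 4 (0.38 log units; beyond the scatter), a modest rise in the number. For compound 4 the estimated value is 4500 nM, with an expected range of 1800 nM to 11000 nM.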

Compound 4, half-maximal inhibitory concentration: 2670 nM
Beside the measured number, compound 4's estimate is 1.7-fold (0.23 log units) above it, within the range that was stated.
By their numbers in this assay, from the lowest: compounds 3 and 4 (each within the scatter of the next); then compounds 2 and 1 (each within the scatter of the next).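

In this assay, fluoro in place of hydrogen on an aromatic carbon gives a 3.7-fold lower number from compound 1 to compound 4 (0.57 log units; beyond the scatter), so a single 2-fluorophenyl does not set the level at this position. 2,4-Difluorophenyl in place of 4-bromophenyl gives a 1.4-fold higher number from compound 3 to compound 4 (0.16 log units; within the scatter), which lies within the scatter, so bromine is not required for the lower numbers in this series. 2,4-Difluorophenyl in place of 3-chlorophenyl gives a 2.6-fold lower number from compound 2 to compound 4 (0.41 log units; beyond the scatter), which lies beyond the scatter. Still open, as far as these compounds go, is whether a methoxy group or an amine on this phenyl ring, or a longer chain to it, would keep this level. No measurement at hand accounts for any of these steps.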